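One Inverted Ring Stereocentre in an Iminosugar Acid

A few compounds are considered here, and "the series" means these few. Any claim that something is new, unique, unknown or untested is made for them only; others in the source may bear on it.

Compound 2 `O=C(O)[C@@H]1NC[C@@H](O)[C@H](O)[C@H]1O` is a small saturated ring bearing hydroxyl groups, a ring nitrogen and a carboxylic acid. Among the measured compounds shown here, in an assay on isolated protein for inhibition of cytosolic endo-beta-N-acetylglucosaminidase (Homo sapiens), tested at 1000 uM (a higher number here means more inhibition at the concentration tested (going by the name of the read-out), a lower number less inhibition), compound 2 gives 50%, the higher of the two numbers measured so far. Its nearest neighbour, compound 1 `O=C(O)[C@H]1NC[C@@H](O)[C@@H](O)[C@@H]1O`, has the same atoms and bonds and gives 28% in this assay. The step of a number 22 percentage points higher from compound 1 to compound 2 (beyond the scatter) shows that configuration alone can move the read-out, because the fact that compounds 1 and 2 differ only in the configuration as drawn and nothing else separates them.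

For the measured compounds named here, compound 3 `O=C(O)[C@@H]1NC[C@H](O)[C@H](O)[C@H]1O` has not yet been measured. the two compounds have the same atoms and bonds and differ only in configuration as drawn: 1 of 4 stereo elements differ; a stereocentre at a saturated ring carbon is drawn R in compound 2 and S in compound 3 Only one stereocentre is inverted here, whereas three changed between compounds 1 and 2, so the single measured step bears on this one only loosely: it shows that stereochemistry matters for this enzyme, but it cannot tell which direction one inversion will take. Compound 3 is therefore expected to show a step of a number 12 percentage points lower from compound 2 to compound 3 (beyond the scatter), most likely a modest fall, with a real chance of no step beyond the scatter. The estimate for compound 3 is 38%, with a range from 12% to 62%.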

Compound 3, a percentage reported as inhibition, at one concentration (the size of the read-out at that concentration, not a potency): 39%
For compound 3 the middle estimate is 1 percentage points below the measured one; measured number inside the range.
By their numbers in this assay, from the lowest: compound 1; then compound 3; then compound 2.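

In this assay, inverting a single stereocentre at a saturated ring carbon, drawn R in compound 2 and S in compound 3, gives a number 11 percentage points lower from compound 2 to compound 3 (beyond the scatter), and the cause can lie only in that configuration: the fact that compounds 2 and 3 differ only in the configuration as drawn. The earlier pair changed three stereocentres at once, so it could not show that one inversion alone is enough to move the read-out. Inverting all four stereocentres gives a number 11 percentage points higher from compound 1 to compound 3 (beyond the scatter), so this assay also separates a pair of mirror images, and again the cause can lie only in configuration: the fact that compounds 1 and 3 differ only in the configuration as drawn.

The compounds shown leave open what each of the other ring stereocentres does when inverted alone, and these numbers are read-outs at one concentration, not potencies. They also leave open whether the read-out would move if an amide replaced the carboxylic acid or if a longer chain were placed on the ring nitrogen.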